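Swapping 4-ethylphenyl for phenethyl at a carbonyl carbon

The source may hold more compounds than are shown below. What is called first, only, known or untested is meant among the compounds shown, and "the series" means these compounds.

Compound 1 `CC(=O)c1ccn(-c2ccc3c(c2)B(O)OC3)c1` gives > 10 ug/mL
Compound 2 `Cc1ccccc1C(=O)c1ccn(-c2ccc3c(c2)B(O)OC3)c1` gives > 10 ug/mL
Compound 3 `CCc1ccc(C(=O)c2ccn(-c3ccc4c(c3)B(O)OC4)c2)cc1` gives > 10 ug/mL

All three results come from an ADME assay on L929 cells (Mus musculus) for cytotoxicity, read by resazurin assay, with a stated time of 72 h (a lower number here means a stronger inhibitor, a higher number a weaker inhibitor), and each one is a limit of the assay, not a number. Compound 3 stands at > 10 ug/mL and this too is only a limit, so it has no exact place among the others.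

Compound 4 `O=C(CCc1ccccc1)c1ccn(-c2ccc3c(c2)B(O)OC3)c1` has not been measured yet. It carries phenethyl in place of 4-ethylphenyl on a carbonyl carbon and otherwise keeps the shared core.

The measured steps at that carbonyl carbon are a step that the two limits leave unreadable from compound 1 to compound 3 and a step that the two limits leave unreadable from compound 2 to compound 3 and a step that the two limits leave unreadable from compound 1 to compound 2 so none of them gives a size. What they share is the limit of > 10 ug/mL in this assay, at which 3 of the 3 values shown sit, and that points in no direction. The step expected is therefore a step that the limit leaves unreadable from compound 3 to compound 4 and no change beyond the usual scatter is expected. The estimate for compound 4 is 15 ug/mL as an expected value, with an expected range from 7 ug/mL to 40 ug/mL and a good chance that only a limit is reported.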

Compound 4, half-maximal inhibitory concentration: > 10 ug/mL
Compound 4: a limit, no number; the forecaster's own chance of this, stated with the estimate: 80%; the middle value lies beyond the limit too.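

Compound 4 gives > 10 ug/mL in this assay as a limit and not a number. Its steps from compound 1, compound 2 and compound 3 cannot be read, so none has a size: the limit of > 10 ug/mL in this assay, at which 4 of the 4 values shown sit.

The compounds shown leave open whether in this assay these groups on the carbonyl carbon differ at all.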